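This account rests on a few compounds, and the source may have more. Where it says the series, first, only, none or still open, it means among the compounds named here.

Measured so far in an ADME assay on RAW264.7 cells (Mus musculus) for cytotoxicity, read by WST assay; a lower number here means that less compound is tolerated, a higher number that more compound is tolerated:

compound 1 `CC(C)(C)OC(=O)N(Cc1ccco1)C(=O)c1ccc(CN2Cc3ccccc3S2(=O)=O)cc1`: > 100000 nM, a limit only
compound 2 `O=C(c1ccc(Cn2c(=O)c3ccccc3[s+]2[O-])cc1)N1CCCCC1`: > 100000 nM, a limit only
compound 3 `NC(=O)c1ccc(CN2C(=O)c3ccccc3S2(=O)=O)cc1`: > 100000 nM, a limit only

Compound 3 therefore stands nowhere in particular on the numbers shown: its own value is a limit of the assay, not a number, and the two further values shown are limits as well. For the measured compounds named here, the whole set rests at the limit of > 100000 nM in this assay, at which 3 of the 3 values shown sit, so no compound can be called more or less tolerated than another, and no step between measured compounds exists that could anchor the size of a change.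

Compound 4 `CC(=O)N(Cc1ccco1)C(=O)c1ccc(CN2C(=O)c3ccccc3S2(=O)=O)cc1` differs from compound 3 in one place: acetyl((furan-2-yl)methyl)amino in place of amino on a carbonyl carbon.

Going by the values given here, with no measured step to lean on, the expectation rests on the limit of > 100000 nM in this assay, at which 3 of the 3 values shown sit, alone: no shift beyond the scatter is expected, and the estimated step of a number no higher from compound 3 to compound 4 (the limit leaves the size open) is taken as flat. Compound 4 is accordingly expected to give 100000 nM, within a range from 40000 nM to 300000 nM, most likely reported once more as a limit rather than a number.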

Compound 4, concentration lethal to 50% of the cells: > 100000 nM
Compound 4: only a limit was reported (the forecaster's own chance of this, stated with the estimate: 75%); the middle value sits exactly at the limit.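

For the compounds shown here, no step from compound 3 to compound 4 can be read in this assay, as both results are limits and not numbers. The compounds shown leave open at what concentration any of them harms the cells, and whether acetyl((furan-2-yl)methyl)amino in place of amino changes that concentration.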